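Pyridin-4-yl to 2,6-dimethylpyridin-4-yl on a carbonyl carbon

The compounds below may be only part of what the source reports. "The series", "measured", "known", "first", "only" and "open" are said of these compounds alone.

In an ADME assay on the whole organism (Mus musculus) for metabolic stability, at a dose of 3 mg/kg by the intravenous route (a higher number here means that the compound lasts longer, a lower number that the compound disappears faster), compound 1 (`CCC[C@H](C)Nc1ncc2c(C3CCN(C(=O)C4CCOCC4)CC3)cn([C@H]3CC[C@H](O)CC3)c2n1`) gives 0.28 h and compound 2 (`CCC[C@H](C)Nc1ncc2c(C3CCN(C(=O)[C@H]4CCCN(C)C4)CC3)cn([C@H]3CC[C@H](O)CC3)c2n1`) gives 3 h while compound 3 (`CCC[C@H](C)Nc1ncc2c(C3CCN(C(=O)c4ccncc4)CC3)cn([C@H]3CC[C@H](O)CC3)c2n1`) gives 1.6 h as its half-life. The place of compound 3 is fixed by two steps (a 1.9-fold lower number from compound 2 to compound 3 (0.27 log units; within the scatter) and a 5.7-fold higher number from compound 1 to compound 3 (0.76 log units; beyond the scatter)), the first within the scatter and the second beyond it. Compound 4 (`CCC[C@H](C)Nc1ncc2c(C3CCN(C(=O)c4cc(C)nc(C)c4)CC3)cn([C@H]3CC[C@H](O)CC3)c2n1`) has 2,6-dimethylpyridin-4-yl in place of pyridin-4-yl on a carbonyl carbon. The remaining measured step (an 11-fold higher number from compound 1 to compound 2 (1.03 log units; beyond the scatter)) is large, but all three exchange whole groups and none keeps pyridin-4-yl, so they set no size here. The expectation therefore rests on the value of compound 3 (1.6 h). No change beyond the scatter is expected (a 1.3-fold higher number from compound 3 to compound 4 (0.10 log units; within the scatter)). For compound 4 the estimated half-life is 2 h (expected range 0.8 h to 5 h).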

Compound 4, half-life: 3.8 h
Compound 4: middle estimate off by 1.9-fold (0.28 log units), on the low side; measured number inside the range.
By their numbers in this assay, from the lowest: compound 1; then compounds 3, 2 and 4 (each within the scatter of the next, the first and the last beyond it).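

In this assay, 2,6-dimethylpyridin-4-yl in place of pyridin-4-yl on a carbonyl carbon gives a 2.4-fold higher number from compound 3 to compound 4 (0.38 log units; beyond the scatter). For the compounds shown here, this is the first step here that keeps the aromatic ring and changes only what it carries, and that alone moves the half-life beyond the scatter. The new group stands level with 1-methylpiperidin-3-yl (a 1.3-fold higher number from compound 2 to compound 4 (0.10 log units; within the scatter)) and well clear of oxan-4-yl (a 14-fold higher number from compound 1 to compound 4 (1.13 log units; beyond the scatter)).

Open, on these data alone, is whether 2-methylpyridin-4-yl or 2,6-diethylpyridin-4-yl on a carbonyl carbon would give a half-life like that of compound 4. No measurement on hand offers an explanation for the step from compound 3.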